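The compounds below may be only part of what the source reports. "The series", "measured", "known", "first", "only" and "open" are said of these compounds alone.

Values in a functional assay on MCF7 cells (Homo sapiens) for cytotoxicity, read by MTT assay, with a stated time of 96 h (on this read-out lower numbers stand for stronger inhibition and higher numbers for weaker inhibition), are these:
- compound 1 `COc1cc(C(=O)c2cn(-c3cccc(Br)c3)cc2-c2ccccc2)cc(OC)c1OC` gives 78 nM
- compound 2 `COc1cc(C(=O)c2cn(-c3ccc([N+](=O)[O-])cc3)cc2-c2ccccc2)cc(OC)c1OC` gives 4000 nM
- compound 3 `COc1cc(C(=O)c2cn(-c3ccc(N)cc3)cc2-c2ccccc2)cc(OC)c1OC` gives 35 nM

Compound 3 holds the lowest number of the three, and its distance to each of the others is beyond the scatter. The next change leads to compound 4 `COc1cc(C(=O)c2cn(-c3cc(OC)c(OC)c(OC)c3)cc2-c2ccccc2)cc(OC)c1OC` and sets 3,4,5-trimethoxyphenyl in place of 4-aminophenyl on an aromatic nitrogen. Two measured steps fall at this same place: a 2.2-fold lower number from compound 1 to compound 3 (0.35 log units; beyond the scatter) is modest and a 51-fold higher number from compound 1 to compound 2 (1.71 log units; beyond the scatter) is large. The step of a 110-fold lower number from compound 2 to compound 3 (2.06 log units; beyond the scatter) is also large and shows how far the number can move with one group changed on that phenyl group. Among the compounds with values here, no measured compound carries a 3,4,5-trimethoxyphenyl group, so these steps give only the span seen at this place and not what the new group will do. Compound 3 sits at the low end of that span with 35 nM so a move to a higher number in this assay is the likelier direction, of modest to large size. An estimated 5.7-fold higher number from compound 3 to compound 4 (0.76 log units; beyond the scatter) is expected on this reasoning. Compound 4 is estimated at 200 nM and expected between 40 nM and 1500 nM on this read-out.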

Compound 4, half-maximal inhibitory concentration: > 5000 nM
Compound 4 ended at the assay's limit (the forecaster's own chance of this, stated with the estimate: 5%); middle value at least 25-fold (1.39 log units) away from the limit.
By their numbers in this assay, from the lowest: compound 3; then compound 1; then compound 2. At a limit, above all of these: compound 4.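

In this assay compound 4 gives > 5000 nM, which is a limit of the assay and not a number: the limit of > 5000 nM in this assay, at which 1 of the 4 values shown sits.

Even read as a floor, two of the steps are large: (an at least 140-fold higher number from compound 3 to compound 4 (2.15 log units; beyond the scatter)) and (an at least 64-fold higher number from compound 1 to compound 4 (1.80 log units; beyond the scatter)). The earlier compounds shown here tied a high number at this place on the aromatic nitrogen to 4-nitrophenyl alone, and compound 4 now adds 3,4,5-trimethoxyphenyl as a second group that moves far from 4-aminophenyl and 3-bromophenyl, so the high end of the span is not specific to the nitro group. The third step (an at least 1.2-fold higher number from compound 2 to compound 4 (0.09 log units; that floor lies within the scatter)) has a floor within the scatter, so no order between 4-nitrophenyl and 3,4,5-trimethoxyphenyl can be stated.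

As far as these compounds go, whether the three methoxy groups act together or one of them is enough remains open, and 4-methoxyphenyl or 3,5-dimethoxyphenyl on the same nitrogen would separate these cases. Also open, from the compounds shown here alone, is how much of the low number of compound 3 rests on its amino group, a question that 4-hydroxyphenyl, 4-dimethylaminophenyl or an unsubstituted phenyl at this place would address.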